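Sulfonyl aryl changes in a cytotoxicity series

The source may hold more compounds than are shown below. What is called first, only, known or untested is meant among the compounds shown, and "the series" means these compounds.

The measured compounds so far:
compound 1, `CCCc1nc2c(C)cc(-c3nc4ccccc4n3C)cc2n1S(=O)(=O)c1ccc(C)cc1`, with 20100 nM;
compound 2, `CCCc1nc2c(C)cc(-c3nc4ccccc4n3C)cc2n1S(=O)(=O)c1ccc(OC)cc1`, with 18300 nM.

Both were read in a functional assay on HeLa cells (Homo sapiens) for cytotoxicity, read by MTT assay; a higher number here means a weaker inhibitor, a lower number a stronger inhibitor. Compound 1 has the highest of the two numbers; its nearest neighbour, compound 2, sits close by, with a 1.1-fold lower number from compound 1 to compound 2 (0.04 log units; within the scatter), so the two are not told apart by this assay.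

Compound 3, `CCCc1nc2c(C)cc(-c3nc4ccccc4n3C)cc2n1S(=O)(=O)c1ccccc1Cl`, has not yet been measured. It differs from compound 1 in one place: 2-chlorophenyl in place of 4-methylphenyl on a sulfonyl sulfur. Within the data shown here, the only step recorded so far also sits on the phenyl attached to the sulfonyl sulfur, and that step, methoxy in place of methyl, stayed within the scatter. On that basis no step beyond the scatter is expected here either, and compound 3 is estimated at 18000 nM, between 7000 nM and 45000 nM, which would be a step of a 1.1-fold lower number from compound 1 to compound 3 (0.05 log units; within the scatter).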

Compound 3, half-maximal inhibitory concentration: > 50000 nM
Compound 3: only a limit was reported (the forecaster's own chance of this, stated with the estimate: 5%); middle value at least 2.7-fold (0.44 log units) away from the limit.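

In this assay compound 3 is reported only as a limit: the limit of > 50000 nM in this assay, at which 1 of the 3 values shown sits.

Even so, the aryl group on the sulfonyl sulfur proves able to move this read-out beyond the scatter, which the earlier methoxy-for-methyl step did not show: 2-chlorophenyl in place of 4-methylphenyl gives an at least 2.4-fold higher number from compound 1 to compound 3 (0.39 log units; beyond the scatter), and 2-chlorophenyl in place of 4-methoxyphenyl gives an at least 2.7-fold higher number from compound 2 to compound 3 (0.43 log units; beyond the scatter). Going by these compounds, both steps are lower bounds, so their full size remains unknown.

Compound 3 changes both the substituent and its place on the phenyl, so the compounds shown do not tell whether the chlorine itself or its place goes with the weaker read-out. On these data alone, how an amine or a carboxylic acid on that phenyl would read also remains open.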